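The source may report more compounds than this note shows. Statements on the series, on what has been measured and on what is new or still open speak of the compounds shown alone.

Three compounds share one core and differ from one another in only one spot each. Compound 1 `COc1cc(-c2nn(-c3ccc(NC(=O)Nc4ccc(Cl)c(C(F)(F)F)c4)cc3)cc2-c2ccncc2)ccc1Cl` gives 1570 nM in a functional assay on SK-MEL-5 cells (Homo sapiens) for antiproliferative activity, read by sulforhodamine B assay, with a stated time of 48 h; a lower number here means a stronger inhibitor, a higher number a weaker inhibitor. Compound 2 `COc1cc(-c2nn(-c3ccc(NC(=O)c4ccc(Cl)c(Cl)c4)cc3)cc2-c2ccncc2)ccc1Cl` gives 1650 nM in this assay. Compound 3 `O=C(Nc1ccc(-n2cc(-c3ccncc3)c(-c3ccc(Cl)c(O)c3)n2)cc1)Nc1ccc(Cl)c(C(F)(F)F)c1` gives 1530 nM in this assay. Going from compound 1 to compound 2, the change 3,4-dichlorophenyl in place of (4-chloro-3-(trifluoromethyl)phenyl)amino on a carbonyl carbon made a 1.1-fold higher number from compound 1 to compound 2 (0.02 log units; within the scatter). The cores of compound 1 and compound 3 differ by hydrogen in place of methyl on an oxygen on an aromatic ring, which made a 1.0-fold lower number from compound 1 to compound 3 (0.01 log units; within the scatter). Among the compounds with values here, compound 4 `O=C(Nc1ccc(-n2cc(-c3ccncc3)c(-c3ccc(Cl)c(O)c3)n2)cc1)c1ccc(Cl)c(Cl)c1` has not yet been measured in this assay; it differs from compound 3 by 3,4-dichlorophenyl in place of (4-chloro-3-(trifluoromethyl)phenyl)amino on a carbonyl carbon, which is the same change at the same place as the one from compound 1 to compound 2. Because that earlier change made a 1.1-fold higher number from compound 1 to compound 2 (0.02 log units; within the scatter), the step from compound 3 to compound 4 is expected to be a 1.0-fold higher number from compound 3 to compound 4 (0.02 log units; within the scatter), a step that stays within the scatter. Compound 4 is therefore estimated at 1600 nM in this assay. The expected range for compound 4 runs from 800 nM to 3200 nM. The measured number will tell whether this holds.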

Compound 4, half-maximal inhibitory concentration: 1150 nM
Compound 4: the middle estimate sits 1.4-fold (0.14 log units) above what was measured, within the range that was stated.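

In this assay, putting 3,4-dichlorophenyl in place of (4-chloro-3-(trifluoromethyl)phenyl)amino on the carbonyl carbon gives a 1.3-fold lower number from compound 3 to compound 4 (0.12 log units; within the scatter), and set beside the same change on the other core, the two steps agree: the same change on two cores in this assay, a 1.1-fold higher number (0.02 log units; within the scatter) from compound 1 to compound 2 and a 1.3-fold lower number (0.12 log units; within the scatter) from compound 3 to compound 4, 1.4-fold (0.15 log units) apart, within the scatter of two such steps. Replacing methyl with hydrogen on the oxygen gives a 1.4-fold lower number from compound 2 to compound 4 (0.16 log units; within the scatter), and this change also agrees across the two cores: the same change on two cores in this assay, a 1.0-fold lower number (0.01 log units; within the scatter) from compound 1 to compound 3 and a 1.4-fold lower number (0.16 log units; within the scatter) from compound 2 to compound 4, 1.4-fold (0.15 log units) apart, within the scatter of two such steps. Within the data shown here, both changes therefore carry from one core to the other without a gap beyond the scatter, but each step is itself within the scatter, so this shows only that neither change moved the number measurably on these cores, not that a change with a large effect would carry over in the same way.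

The compounds shown leave open what an amine or a carboxylic acid on the phenyl ring of the group on the carbonyl carbon would do. They also leave open whether a longer chain in place of methyl on the oxygen would give a step beyond the scatter.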